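A few compounds are considered here, and "the series" means these few. Any claim that something is new, unique, unknown or untested is made for them only; others in the source may bear on it.

Of the compounds shown here, three on the shared core have been measured so far in a functional assay on MCF7 cells (Homo sapiens) for antiproliferative activity, read by MTT assay, with a stated time of 24 h (a lower number here means a stronger inhibitor, a higher number a weaker inhibitor), and all remain weak. Compound 1 (`COC(=O)c1scc(-c2ccc(NC(=O)c3cccc(C(F)(F)F)c3)cc2)c1OC`) gives 26200 nM in this series. Compound 2 (`COC(=O)c1scc(-c2ccc(NC(=O)c3ccc(F)c(Cl)n3)cc2)c1OC`) gives 10300 nM and compound 3 (`COC(=O)c1scc(-c2ccc(NC(=O)c3cccc(I)c3)cc2)c1OC`) gives 12300 nM on the same read-out.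

Compound 3 sits level with compound 2 and clearly under compound 1: a 1.2-fold higher number from compound 2 to compound 3 (0.08 log units; within the scatter) stays within the scatter, while a 2.1-fold lower number from compound 1 to compound 3 (0.33 log units; beyond the scatter) lies beyond it but is modest.

Compound 4 (`COC(=O)c1scc(-c2ccc(NC(=O)c3ccc(C#N)nc3)cc2)c1OC`) carries 6-cyanopyridin-3-yl in place of 3-iodophenyl on a carbonyl carbon is the whole change.

Among the compounds with values here, two measured steps bear on this swap most directly. Compound 2 is the one measured pyridine, and a 1.2-fold higher number from compound 2 to compound 3 (0.08 log units; within the scatter) shows no separation from the iodophenyl compound. Replacing the aromatic group of compound 1 gave a 2.5-fold lower number from compound 1 to compound 2 (0.41 log units; beyond the scatter) and this too is modest. Within the data shown here, no measured compound carries a nitrile, so the direction of any shift remains open.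

The estimated step is a 1.1-fold higher number from compound 3 to compound 4 (0.06 log units; within the scatter) and so no shift beyond the scatter is expected. In this assay compound 4 is expected at 14000 nM within an estimated range of 6000 nM to 33000 nM for now.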

Compound 4, half-maximal inhibitory concentration: 9540 nM
Beside the measured number, compound 4's estimate is 1.5-fold (0.17 log units) above it; measured number inside the range.
By their numbers in this assay, from the lowest: compounds 4, 2 and 3 (each within the scatter of the next); then compound 1.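

In this assay the place on the carbonyl carbon whose other neighbour is the amide-type nitrogen accepts 6-cyanopyridin-3-yl with no separation from the earlier groups: a 1.3-fold lower number from compound 3 to compound 4 (0.11 log units; within the scatter) and a 1.1-fold lower number from compound 2 to compound 4 (0.03 log units; within the scatter) both stay within the scatter, although the entering group brings a nitrile and hydrogen-bond acceptors that 3-iodophenyl does not have. With a 2.7-fold lower number from compound 1 to compound 4 (0.44 log units; beyond the scatter) beyond the scatter but modest, compound 1 stays apart from compounds 2, 3 and 4, and 3-(trifluoromethyl)phenyl is the only group shown that separates from the rest. No measurement is at hand to explain this flat picture.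

All four compounds carry an aromatic ring at this place and all remain weak, leaving open whether an amine or a carboxylic acid on that ring, or a saturated ring or a longer alkyl chain on the carbonyl carbon, would move the number beyond the scatter. The contribution of the nitrile itself also stays unresolved, with no pair among the compounds shown differing in that group alone.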